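This account rests on a few compounds, and the source may have more. Where it says the series, first, only, none or still open, it means among the compounds named here.

Compound 1 `COc1ccc(C(=O)/C=C/c2cc(OC)c(OC)cc2OC)cc1` and compound 2 `COc1cc(OC)c(OC)cc1/C=C/C(=O)c1ccccc1` share the same core and differ only in one place on the ring that sits next to the carbonyl. In a functional assay on cells (Erythrocyte, Rattus norvegicus) for inhibition, read by hemolysis, with a stated time of 1 h (a lower number here means a stronger inhibitor, a higher number a weaker inhibitor), compound 1 gives 2.18 ug/mL, and compound 2 gives 2.23 ug/mL. Compound 2 therefore has the higher of the two numbers, yet the gap to compound 1 is within the scatter, so the two cannot be told apart: a 1.0-fold higher number from compound 1 to compound 2 (0.01 log units; within the scatter).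

Compound 3 `COc1cc(OC)c(OC)cc1/C=C/C(=O)c1ccc(Br)cc1` has not yet been measured. It differs from compound 2 by bromo in place of hydrogen on an aromatic carbon. Among the measured compounds shown here, no measured step introduces a bromo; the one measured step, hydrogen in place of methoxy on that same ring, stayed within the scatter. The expectation for compound 3 is therefore a step of about a 1.0-fold lower number from compound 2 to compound 3 (0.01 log units; within the scatter), that is, no change beyond the scatter. Compound 3 is estimated at 2.2 ug/mL, with a range from 1.1 ug/mL to 4.5 ug/mL.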

Compound 3, half-maximal inhibitory concentration: 2.3 ug/mL
For compound 3 the middle estimate is 1.0-fold (0.02 log units) below the measured one; low and high end bracket the measured number.
By their numbers in this assay, from the lowest: compounds 1, 2 and 3 (each within the scatter of the next).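

In this assay, bromo in place of hydrogen gives a 1.0-fold higher number from compound 2 to compound 3 (0.01 log units; within the scatter) and bromo in place of methoxy gives a 1.1-fold higher number from compound 1 to compound 3 (0.02 log units; within the scatter). The position para to a large group has now carried hydrogen, methoxy and bromo with no step beyond the scatter, so a single bromine atom joins the two earlier groups in leaving the number unchanged, a comparison that the earlier pair alone could not make. No measurement is available to explain why these three groups read alike.

From the compounds shown here alone, whether a group of another kind, such as an amine or a carboxylic acid, would also leave the number in place remains open. The same holds for a longer chain at this position, and for bromo on another carbon of this ring.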